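Swapping Butylcarbonyl for Nitro on the Shared Core

This account rests on a few compounds, and the source may have more. Where it says the series, first, only, none or still open, it means among the compounds named here.

Measured compounds:
- compound 1 `CC(=O)Oc1ccccc1C(=O)O[C@H]1CO[C@H]2[C@@H]1OC[C@H]2OC(=O)c1ccccc1O` gives 0.019 h
- compound 2 `CCCCC(=O)O[C@@H]1CO[C@H]2[C@@H]1OC[C@@H]2OC(=O)c1ccccc1OC(C)=O` gives 0.0117 h
- compound 3 `COc1ccc(C(=O)O[C@@H]2CO[C@H]3[C@@H]2OC[C@@H]3OC(=O)c2ccccc2OC(C)=O)cc1` gives 0.0183 h

These three were run in an ADME assay on a cell-free system (plasma, Homo sapiens) for metabolic stability, with Plasma (Rattus norvegicus) as the target, read by HPLC, at pH 7.4; a lower number here means that the compound disappears faster, a higher number that the compound lasts longer. Compound 2 has the lowest of the three numbers, but its neighbours sit close: the step of a 1.6-fold lower number from compound 1 to compound 2 (0.21 log units; within the scatter) and the step of a 1.6-fold higher number from compound 2 to compound 3 (0.19 log units; within the scatter) both lie within the scatter, as does a 1.0-fold lower number from compound 1 to compound 3 (0.02 log units; within the scatter). So on the evidence so far the three compounds cannot be told apart in this assay.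

Compound 4 `CC(=O)Oc1ccccc1C(=O)O[C@H]1CO[C@H]2[C@@H]1OC[C@H]2O[N+](=O)[O-]` is not yet measured. It differs from compound 2 in one place: nitro in place of butylcarbonyl on an oxygen on a saturated carbon.

The two measured steps that bear on this change are those that also swap the group on that same oxygen, from compound 1 to compound 2 and from compound 2 to compound 3. Both were within the scatter, although both kept a carbonyl group at that position, which the nitro group in compound 4 does not. With nothing in the measured set pointing in either direction, the expected step of a 1.3-fold higher number from compound 2 to compound 4 (0.11 log units; within the scatter) is no change beyond the scatter. Compound 4 is therefore estimated at 0.015 h, with a range from 0.006 h to 0.04 h.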

Compound 4, half-life: 0.00314 h
Compound 4: the middle estimate sits 4.8-fold (0.68 log units) above what was measured, outside the stated range (below it).
By their numbers in this assay, from the lowest: compound 4; then compounds 2, 3 and 1 (each within the scatter of the next).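

In this assay, this oxygen on a saturated carbon proves sensitive to the group it carries: butylcarbonyl, (4-methoxyphenyl)carbonyl and (2-hydroxyphenyl)carbonyl all sit within the scatter of one another, yet replacing them with nitro gives a 3.7-fold lower number from compound 2 to compound 4 (0.57 log units; beyond the scatter) and a 5.8-fold lower number from compound 3 to compound 4 (0.77 log units; beyond the scatter) and a 6.1-fold lower number from compound 1 to compound 4 (0.78 log units; beyond the scatter). The earlier compounds shown here varied this position only among groups joined through a carbonyl, so they could not show that a larger change here moves the half-life beyond the scatter, and compound 4 now stands apart as the shortest-lived of the four. Nothing in the data shown explains why the number falls with nitro.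

The compounds shown cannot say whether this drop belongs to nitro itself or would also appear with another group lacking a carbonyl on that oxygen, such as a simple methyl ether or a sulfonate ester. They also leave open which part of compound 4 is lost, since the read-out follows the disappearance of the whole compound and not the site where it breaks.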